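Methyl in Place of Methoxy at the Serotonin 1E Receptor

A few compounds are considered here, and "the series" means these few. Any claim that something is new, unique, unknown or untested is made for them only; others in the source may bear on it.

Measured compounds:
- compound 1, `Fc1ccc(-c2n[nH]cc2N2CCCNCC2)cc1`: > 10000 nM in an assay on isolated protein for binding affinity to 5-hydroxytryptamine receptor 1E (Homo sapiens); on this read-out lower numbers stand for stronger inhibition and higher numbers for weaker inhibition
- compound 2, `COc1ccccc1-c1n[nH]cc1N1CCNCC1`: > 10000 nM
- compound 3, `COc1ccc(-c2n[nH]cc2N2CCNCC2)cc1`: > 10000 nM

Each of these three values is a limit of the assay rather than a number. Compound 1 stands at its limit. Compound 2 stands at its limit. Compound 3 likewise stands at its limit, so its position can be given only as a limit, and nothing separates it from the other two on the numbers shown, since all three sit at the limit of > 10000 nM in this assay, at which 3 of the 3 values shown sit. Within the data shown here, no step between two measured compounds that differ in one place is available, so no measured step size exists to lean on.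

Compound 4 `Cc1ccc(-c2n[nH]cc2N2CCNCC2)cc1` differs from compound 3 in one place: methyl in place of methoxy on an aromatic carbon. In this assay no step beyond the scatter is expected in either direction, because every compound shown so far stands at the limit of > 10000 nM in this assay, at which 3 of the 3 values shown sit. Compound 4 is therefore expected to remain at the limit as well, with an estimate of 20000 nM and a range from 5000 nM to 100000 nM. The step that this estimate implies, a step that the limit leaves unreadable from compound 3 to compound 4, is expected to lie within the scatter.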

Compound 4, inhibition constant: > 10000 nM
Compound 4 gave a limit, no number (the forecaster's own chance of this, stated with the estimate: 85%); the middle value is on the limit's open side.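

In this assay compound 4 gives > 10000 nM as a limit and not a number. No step can be read from compound 3 to compound 4, because both stand at the same limit: the limit of > 10000 nM in this assay, at which 4 of the 4 values shown sit. The compounds shown leave open whether methyl and methoxy differ at all on this receptor, and what would bring a measurable value.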